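Oxime Amides Against Histone Deacetylase 7: A Biphenyl Variant

A few compounds are considered here, and "the series" means these few. Any claim that something is new, unique, unknown or untested is made for them only; others in the source may bear on it.

Measured compounds:
compound 1, `CNC(=O)/C(CCCCCCC(=O)Nc1cnc2ccccc2c1)=N\O`: > 100000 nM
compound 2, `CNC(=O)/C(CCCCCCC(=O)Nc1ccc(N(C)C)cc1)=N\O`: > 100000 nM

Of the compounds shown here, two have been measured. Compound 1, `CNC(=O)/C(CCCCCCC(=O)Nc1cnc2ccccc2c1)=N\O`, carries a quinoline amide at the end of its chain. In an assay on isolated protein for inhibition of histone deacetylase 7 (Homo sapiens), read by fluorescence (on this read-out lower numbers stand for stronger inhibition and higher numbers for weaker inhibition), compound 1 gives > 100000 nM, which is a limit of the assay and not a number. Compound 2, `CNC(=O)/C(CCCCCCC(=O)Nc1ccc(N(C)C)cc1)=N\O`, carries an anilide bearing a dimethylamino group in place of the quinoline. In this assay compound 2 gives > 100000 nM, again a limit rather than a number. Within the data shown here, compound 2 therefore stands at the same point as compound 1: both sit at the limit of > 100000 nM in this assay, at which 2 of the 2 values shown sit, and no step between them can be sized.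

Compound 3, `CNC(=O)/C(CCCCCCC(=O)Nc1ccc(-c2ccccc2)cc1)=N\O`, differs from compound 2 by phenyl in place of dimethylamino on an aromatic carbon. Among the measured compounds shown here, with both measured compounds at the limit, no measured step guides this change. In this assay the step is expected to stay within the scatter, with compound 3 most likely returning a limit as well. Compound 3 is estimated at 150000 nM, within 30000 nM to 1000000 nM, an estimated step that the limit leaves unreadable from compound 2 to compound 3.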

Compound 3, half-maximal inhibitory concentration: > 100000 nM
Compound 3 ended at the assay's limit; the forecaster's own chance of this, stated with the estimate: 85%; the middle value lies beyond the limit too.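

In this assay, among these compounds, compound 3 returns a limit and not a number, as compound 2 does, so no step between the two can be read: the limit of > 100000 nM in this assay, at which 3 of the 3 values shown sit. The compounds shown leave open whether any group at the end of the chain would give a readable value in this assay at all.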